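This account rests on a few compounds, and the source may have more. Where it says the series, first, only, none or still open, it means among the compounds named here.

Measured so far in a functional assay on M21 cells (Homo sapiens) for antiproliferative activity, read by sulforhodamine B assay, with a stated time of 48 h; a lower number here means a stronger inhibitor, a higher number a weaker inhibitor:
- compound 1 `CCc1ccc(NS(=O)(=O)c2ccc(N3CCNC3=O)cc2)cc1`: compound 1 gives 480 nM
- compound 2 `Cc1ccccc1NS(=O)(=O)c1ccc(N2CCNC2=O)cc1`: compound 2 gives 150 nM
- compound 3 `COc1ccccc1NS(=O)(=O)c1ccc(N2CCNC2=O)cc1`: compound 3 gives 300 nM

Compound 3 holds the second highest of the three numbers; its nearest neighbour is compound 1 (a 1.6-fold lower number from compound 1 to compound 3 (0.20 log units; within the scatter)) and its furthest is compound 2 (a 2.0-fold higher number from compound 2 to compound 3 (0.30 log units; within the scatter)), neither gap beyond the scatter. Compound 4 `COc1cccc(NS(=O)(=O)c2ccc(N3CCNC3=O)cc2)c1` differs from compound 3 by 3-methoxyphenyl in place of 2-methoxyphenyl on a sulfonamide nitrogen. Among the measured compounds shown here, no measured step involves a 3-methoxyphenyl, so the bearing is indirect: the replacements on the sulfonamide nitrogen seen so far gave a 3.2-fold lower number from compound 1 to compound 2 (0.51 log units; beyond the scatter) and a 1.6-fold lower number from compound 1 to compound 3 (0.20 log units; within the scatter), at most a modest shift. The expectation for compound 4 is therefore a step within or near the scatter, a 1.2-fold higher number from compound 3 to compound 4 (0.07 log units; within the scatter). Compound 4 is estimated at 350 nM, with a range of 150 nM to 800 nM in this assay.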

Compound 4, half-maximal inhibitory concentration: 65 nM
For compound 4 the middle estimate is 5.4-fold (0.73 log units) above the measured one, and the stated range ends above it.
By their numbers in this assay, from the lowest: compound 4; then compounds 2, 3 and 1 (each within the scatter of the next, the first and the last beyond it).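

Moving the methoxy from 2-methoxyphenyl to 3-methoxyphenyl on the sulfonamide nitrogen, with the same atoms, gives a 4.6-fold lower number from compound 3 to compound 4 (0.66 log units; beyond the scatter) and shows that the placement of this group alone changes the number. Among the compounds shown here, compound 4 is also the only compound here with steps beyond the scatter to all the others, with a 2.3-fold lower number from compound 2 to compound 4 (0.36 log units; beyond the scatter) and a 7.4-fold lower number from compound 1 to compound 4 (0.87 log units; beyond the scatter) as the other two. No evidence is available on what lies behind this difference.

From the compounds shown here alone, it remains open whether 3-methylphenyl or 4-methoxyphenyl would match compound 4. Also open, going by these compounds, is how 3-aminophenyl or 3-carboxyphenyl would fare on the same nitrogen.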